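Pyrazinyl to pyrimidinyl: a solubility step in a biaryl amide series

The compounds below may be only part of what the source reports. "The series", "measured", "known", "first", "only" and "open" are said of these compounds alone.

Measured compounds:
compound 1, `CCCOc1ccc(C[C@@H](Cc2ccccc2)C(=O)O)cc1CNC(=O)c1ccc(-c2ccccc2)cc1`, < 1 ug/mL
compound 2, `CCCOc1ccc(C[C@@H](Cc2ccccc2)C(=O)O)cc1CNC(=O)c1ccc(-c2cnccn2)cc1`, 32.2 ug/mL

In a physicochemical assay for solubility, read by HPLC, in phosphate buffer, measured as thermodynamic solubility, with a stated time of 48 h, at pH 7.2 (on this read-out higher numbers stand for higher solubility and lower numbers for lower solubility), compound 1 reports only a limit of the assay, < 1 ug/mL, not a number. Among the compounds with values here, compound 2 gives 32.2 ug/mL in this assay, and it carries the only number among the measured pair. Within the data shown here, the one measured step, an at least 32-fold higher number from compound 1 to compound 2 (1.50 log units; beyond the scatter), rests on (the limit of < 1 ug/mL in this assay, at which 1 of the 2 values shown sits).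

Compound 3, `CCCOc1ccc(C[C@@H](Cc2ccccc2)C(=O)O)cc1CNC(=O)c1ccc(-c2cncnc2)cc1`, has not been measured. Its difference from compound 2 is pyrimidin-5-yl in place of pyrazin-2-yl on an aromatic carbon. The step from compound 1 to compound 2 exchanged a carbon-only ring for a nitrogen-containing one, whereas the change to compound 3 keeps the same atoms and the same count of hydrogen-bond acceptors, so that large step bears only loosely on it. Among the measured compounds shown here, no measured step compares two such nitrogen-containing rings. For compound 3 the expected step is a 1.1-fold lower number from compound 2 to compound 3 (0.03 log units; within the scatter), within the scatter in either direction. The estimate for compound 3 in this assay is therefore 30 ug/mL, with a range from 10 ug/mL to 90 ug/mL.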

Compound 3, solubility: 190 ug/mL
Compound 3: the middle estimate sits 6.3-fold (0.80 log units) below what was measured, and the stated range ends below it.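

With the same atoms and the same counted hydrogen-bond acceptors, the arrangement of the two ring nitrogens alone separates two compounds in this assay: the step is a 5.9-fold higher number from compound 2 to compound 3 (0.77 log units; beyond the scatter), so at this position, para to a large group, these two nitrogen-containing rings do not read alike. Within the data shown here, the earlier pair could show only a carbon-only ring giving way to a nitrogen-containing one, whereas this pair is the first comparison of two nitrogen-containing rings. The step from the phenyl group, an at least 190-fold higher number from compound 1 to compound 3 (2.27 log units; beyond the scatter), rests on a limit of the assay and not on a number: the limit of < 1 ug/mL in this assay, at which 1 of the 3 values shown sits.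

As far as these compounds go, whether a pyridazine ring, with its two nitrogens arranged another way, or a pyridine ring, with a single nitrogen, would read nearer to compound 2 or to compound 3 in this assay stays open, as does the effect of an amine or a methoxy group on the ring. The compounds shown also keep the shared core constant, so it remains open whether this exchange of rings would give a like step with a longer chain on the core.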